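A few compounds are considered here, and "the series" means these few. Any claim that something is new, unique, unknown or untested is made for them only; others in the source may bear on it.

Of the compounds shown here, three sharing one core have been measured in an assay on L1.2 cells for binding affinity to C-C chemokine receptor type 8 (Homo sapiens); on this read-out lower numbers stand for stronger inhibition and higher numbers for weaker inhibition. Compound 1 `O=C(Nc1ccc(S(=O)(=O)N2CCOCC2)c2ccccc12)c1ccccc1` gives 7750 nM. Compound 2 `CN1CCN(S(=O)(=O)c2ccc(NC(=O)c3ccccc3)c3ccccc23)CC1` reaches only > 30000 nM, which is a limit of the assay and not a number. Among the compounds with values here, the single measured step, an at least 3.8-fold higher number from compound 1 to compound 2 (0.58 log units; beyond the scatter), changes the group on the sulfonyl sulfur and rests on (the limit of > 30000 nM in this assay, at which 1 of the 3 values shown sits). Compound 3 `CCC(=O)N1CCC(NS(=O)(=O)c2ccc(NC(=O)c3ccccc3C)c3ccccc23)CC1` gives 2.5 nM, the lowest of the two numbers and far from compound 1. Compound 4 `Cc1ccccc1C(=O)Nc1ccc(S(=O)(=O)NC2CCN(C(=O)CCN)CC2)c2ccccc12` has not yet been measured; it differs from compound 3 by amino in place of hydrogen on a saturated chain carbon, two bonds along the chain from a carbonyl carbon. Within the data shown here, the one measured step concerns the sulfonyl substituent and says nothing about an amino group on the propanoyl chain, so no measured evidence bears directly on this change. For compound 4 the expected step is therefore a 1.6-fold higher number from compound 3 to compound 4 (0.20 log units; within the scatter), not beyond the scatter, with the uncertainty lying mainly toward weaker binding. Compound 4 is accordingly estimated at 4 nM, with a likely range from 1 nM to 25 nM.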

Compound 4, inhibition constant: 11.3 nM
For compound 4 the middle estimate is 2.8-fold (0.45 log units) below the measured one; the measured number falls inside the stated range.
By their numbers in this assay, from the lowest: compound 3; then compound 4; then compound 1. At a limit, above all of these: compound 2.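

Amino in place of hydrogen on a saturated chain carbon, two bonds along the chain from a carbonyl carbon, brings a 4.5-fold higher number from compound 3 to compound 4 (0.66 log units; beyond the scatter) in this assay and so shows that this place on the propanoyl chain responds to a small change, if only modestly. Within the data shown here, the earlier step concerned only the group on the sulfonyl sulfur, so this is the first measured step that reads anything from the propanoyl end of the molecule. With the amino group present, compound 4 still gives 11.3 nM in this assay, so the change weakens binding without abolishing it.

The compounds shown leave open whether a dimethylamino group, a hydroxyl group, a carboxylic acid or a longer chain carrying the amine in the same place would lie nearer to compound 3 or further from it. Nothing measured among the compounds shown speaks to what lies behind this step.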